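A few compounds are considered here, and "the series" means these few. Any claim that something is new, unique, unknown or untested is made for them only; others in the source may bear on it.

Measured so far in an ADME assay on Vero cells (Chlorocebus sabaeus) for cytotoxicity, with a stated time of 72 h, tested at 10 ug/mL; on this read-out lower numbers stand for a weaker effect and higher numbers for a stronger effect at the one concentration tested:

compound 1, `O=c1[nH]nc2n(c1=O)CCN2c1ccccc1`: 7%
compound 2, `COc1ccc(N2CCN/C2=N\N)cc1`: 0%
compound 3, `COc1ccccc1N1CCn2c1n[nH]c(=O)c2=O`: 26%

Compound 3 carries the core of the series together with a methoxy group and gives the highest of the three numbers in this assay. Compound 1 differs from it by one change, (hydrogen in place of methoxy on an aromatic carbon), and the step of a number 19 percentage points lower from compound 3 to compound 1 (beyond the scatter) is a loss that lies beyond the scatter. Compound 2 has a different core; how it differs from the core of compound 3 is not broken down here, and the two values simply show compound 2 at the bottom of the set, separated from compound 3 by a gap beyond the scatter and from compound 1 by a gap within it.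

Compound 4, `N/N=C1\NCCN1c1ccccc1`, is not yet measured. It is obtained from compound 2 by hydrogen in place of methoxy on an aromatic carbon. Among the compounds with values here, this is the same kind of change as the one from compound 3 to compound 1, but not the same: in the measured pair the place is ortho to a large group, whereas here it is para to a group of 7 heavy atoms, and the cores differ as well. Since compound 2 already gives 0%, a further loss of the size seen from compound 3 to compound 1 cannot appear on this read-out. Compound 4 is therefore expected to stay within the scatter of compound 2, with an estimated step of a number 3 percentage points higher from compound 2 to compound 4 (within the scatter). The estimate for compound 4 in this assay is 3%, with a range from 0% to 12%.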

Compound 4, a percentage reported as inhibition, at one concentration (the size of the read-out at that concentration, not a potency): 0%
The estimate for compound 4 lay 3 percentage points above the measured number; the range from low to high includes it.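

Hydrogen in place of methoxy on an aromatic carbon shows no change at the digits printed from compound 2 to compound 4 (within the scatter) in this assay. Set beside the earlier step, the same kind of change does not read the same on the two cores, so a step seen on one core cannot simply be carried over to the other: the same change on two cores in this assay, a number 19 percentage points lower (beyond the scatter) from compound 3 to compound 1 and no change at the digits printed (within the scatter) from compound 2 to compound 4, 19 percentage points apart, beyond the scatter of two such steps

This does not show that the core alone sets the size of the step, since the place of the methoxy group also differs between the two pairs, and compound 2 gives 0%, which leaves a loss from it no room to appear on this read-out; two pairs give a contrast between two cases, not a rule for the series.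

Still open, going by these compounds, is whether methoxy in the same place on both cores would give steps that agree, which would separate the effect of the core from that of the place. Also open, on these data alone, is how other groups at these places would read on either core, for instance an amine, a carboxylic acid or a longer alkoxy chain in place of methoxy.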